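Acetyl to dimethylamino on the phenyl of compound 1

The source may hold more compounds than are shown below. What is called first, only, known or untested is meant among the compounds shown, and "the series" means these compounds.

Compound 1 `COc1cc(C)cc(-c2c(-c3ccnc(-c4ccc(C(C)=O)cc4)c3)cnn2CC#N)c1` is measured in a functional assay on OVCAR-8 cells (Homo sapiens) for cytotoxicity, read by sulforhodamine B assay, with a stated time of 48 h, tested at 1 uM (a lower number here means a stronger effect, a higher number a weaker effect of the compound at the concentration tested), where compound 1 gives 8%. Compound 2 `COc1cc(C)cc(-c2nn(CC#N)cc2-c2ccc(-c3cccc(C(C)=O)c3)nc2)c1` gives 14% in this assay, and compound 3 `COc1cc(C)cc(-c2nn(CC#N)cc2-c2ccnc(-c3ccc(N(C)C)cc3)c2)c1` gives 14%. Compound 1 sits together with the other two: its number differs from each of theirs by an amount within the usual scatter, so no order among the three can be read from these data. Compound 4 `COc1cc(C)cc(-c2c(-c3ccnc(-c4ccc(N(C)C)cc4)c3)cnn2CC#N)c1` has not been measured. It differs from compound 1 in one place: dimethylamino in place of acetyl on an aromatic carbon. Among the compounds with values here, no step between measured compounds shows how such a change plays out; compound 3 carries a dimethylamino group on a related framework and gives 14%, close to compound 1. The change is therefore expected to stay within the scatter, a number 4 percentage points higher from compound 1 to compound 4 (within the scatter). Compound 4 is estimated at 12%, with a range of 3% to 28%.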

Compound 4, a percentage reported as activity, at one concentration (the size of the read-out at that concentration, not a potency): 12%
For compound 4 middle estimate and measured number coincide at the digits printed; measured number inside the range.
By their numbers in this assay, from the lowest: compounds 1, 4, 2 and 3 (each within the scatter of the next).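

In this assay, within the data shown here, the exchange of acetyl for dimethylamino on this phenyl gives a number 4 percentage points higher from compound 1 to compound 4 (within the scatter) and so provides a direct step on a single framework, which the earlier compounds lacked. At the one concentration tested, the read-out does not separate these two groups at this position. Nothing measured here accounts for this result. Still open, on these data alone, is whether a carboxylic acid or a primary amine at the same position would move the read-out beyond the scatter.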